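Adding an Ethoxycarbonyl Cap to a Potent Hydroxamic Acid

This account rests on a few compounds, and the source may have more. Where it says the series, first, only, none or still open, it means among the compounds named here.

Of the compounds shown here, two have been tested in an assay on isolated protein for inhibition of protein deacetylase HDAC6 (Homo sapiens), read by fluorescence, with a stated time of 17 h; a higher number here means a weaker inhibitor, a lower number a stronger inhibitor. Compound 2 `Nc1cccc(-c2csc(NC(=O)CCCCCC(=O)NO)n2)c1` gives 3.3 nM in this assay. Compound 1 `CCOC(=O)Nc1cccc(-c2csc(NC(=O)CCCCCC(=O)Nc3ccccc3N)n2)c1`, which carries a different end group on its linker, reaches only a limit of the assay, reported as > 30000 nM. For the measured compounds named here, compound 2 therefore holds the only measured number, the other entry being the limit of > 30000 nM in this assay, at which 1 of the 2 values shown sits, rather than a value.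

Compound 3 `CCOC(=O)Nc1cccc(-c2csc(NC(=O)CCCCCC(=O)NO)n2)c1` is built from compound 2 by a single change: ethoxycarbonyl in place of hydrogen on a nitrogen on an aromatic ring. The hydroxamic acid end of the molecule, shared with compound 2, is kept unchanged; only the group on the nitrogen on the aromatic ring is altered.

Compound 1 and compound 3 share that ethoxycarbonyl group, but they differ at the other end of the chain as well, so no conclusion can be drawn from the limit of compound 1 for compound 3. With the hydroxamic acid retained, the step from compound 2 is expected to be small, a 1.5-fold higher number from compound 2 to compound 3 (0.18 log units; within the scatter), and within or just beyond the usual scatter. Compound 3 is accordingly estimated at 5 nM in this assay, with a likely range of 1.5 nM to 20 nM.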

Compound 3, half-maximal inhibitory concentration: 0.79 nM
Compound 3: middle estimate off by 6.3-fold (0.80 log units), on the high side; measured number outside the range, below it.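

In this assay, the nitrogen on the aromatic ring proves open to substitution: the change gives a 4.2-fold lower number from compound 2 to compound 3 (0.62 log units; beyond the scatter), so the amino group does not have to stay unsubstituted for strong inhibition, and the ethoxycarbonyl group brings a real gain here rather than a loss. Compound 3 also gives the first clean view of the other end of the chain, since it differs from compound 1 in one place only: hydroxy in place of 2-aminophenyl on an amide-type nitrogen gives an at least 37000-fold lower number from compound 1 to compound 3 (4.57 log units; beyond the scatter), a step that starts from a limit of the assay and not from a number. For the compounds shown here, nothing measured so far accounts for either step.

Going by these compounds, it remains open whether the gain belongs to the whole ethoxycarbonyl group or to part of it, a question that a methoxycarbonyl or an acetyl group on the same nitrogen could help to answer. Also open, on these data alone, is how a shorter or longer chain between the shared core and the hydroxamic acid would behave with this group in place, and how compound 3 fares against other deacetylases.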